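The source may hold more compounds than are shown below. What is called first, only, known or untested is meant among the compounds shown, and "the series" means these compounds.

Three sulfonamides sharing one core have been measured in an assay on isolated protein for inhibition of alkaline phosphatase, tissue-nonspecific isozyme (Homo sapiens); on this read-out higher numbers stand for weaker inhibition and lower numbers for stronger inhibition. Compound 2 `COc1ccc(Cl)cc1S(=O)(=O)Nc1cncc(-c2ccccc2C)c1` gives 178 nM, the lowest of the three numbers shown, though compound 1 `COc1ccc(Cl)cc1S(=O)(=O)Nc1cncc(C(=O)Nc2ccccc2)c1`, which gives 310 nM, lies within the scatter of it, as the step of a 1.7-fold lower number from compound 1 to compound 2 (0.24 log units; within the scatter) shows. Compound 3 `COC(=O)c1ccc(OC)c(S(=O)(=O)Nc2cccnc2)c1` gives 1510 nM, a gap from compound 2 that lies beyond the scatter.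

Compound 4 `COc1ccc(Cl)cc1S(=O)(=O)Nc1cncc(-c2ccc(Cl)cc2)c1` is not yet measured. It differs from compound 2 in one place: 4-chlorophenyl in place of 2-methylphenyl on an aromatic carbon. Within the data shown here, the only measured step that touches this position is a 1.7-fold lower number from compound 1 to compound 2 (0.24 log units; within the scatter), where an amide-linked group was exchanged for the 2-methylphenyl group and the number moved within the scatter. Among the measured compounds shown here, no measured pair shows the exchange of one aryl group for another at this position, so nothing more specific can be read from the data. Given that the one step at this position stayed within the scatter, a change of similar size is expected here, with no clear direction. The estimate for compound 4 in this assay is 200 nM, with a range from 70 nM to 600 nM, which means an expected step of a 1.1-fold higher number from compound 2 to compound 4 (0.05 log units; within the scatter) from compound 2.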

Compound 4, half-maximal inhibitory concentration: 198 nM
Compound 4: middle estimate off by 1.0-fold (0.00 log units), on the high side; the range from low to high includes it.
By their numbers in this assay, from the lowest: compounds 2, 4 and 1 (each within the scatter of the next); then compound 3.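

Among these compounds, this is the first look at one aryl group exchanged for another at this position, on an aromatic carbon two atoms from the ring nitrogen of the shared core, and in this assay the exchange of 2-methylphenyl for 4-chlorophenyl leaves the number within the scatter (a 1.1-fold higher number from compound 2 to compound 4 (0.05 log units; within the scatter)). The exchange of phenylcarbamoyl for 4-chlorophenyl also stays within the scatter (a 1.6-fold lower number from compound 1 to compound 4 (0.19 log units; within the scatter)), so the three groups seen here at this position, one of them amide-linked and two of them directly attached aryl rings with different substituents, cannot be told apart by this read-out. No supporting measurement on hand bears on what lies behind this similarity.

As far as these compounds go, all three groups carry a six-membered aromatic ring of carbon only, so it remains open whether the number would hold with something of a different kind at this position, such as a carboxylic acid, an amine or a longer alkyl chain. Also open, from the compounds shown here alone, is whether a chlorine or a methyl group matters at all on the aryl ring, which a plain phenyl ring directly attached to the core would help to show.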